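Swapping sulfamoyl for dimethylamino on a pyridinyl-bearing core

The source may hold more compounds than are shown below. What is called first, only, known or untested is meant among the compounds shown, and "the series" means these compounds.

Measured so far:
- compound 1, `CN(C)c1cccc(Nc2nccc(-c3cccs3)n2)c1`: 2400 nM
- compound 2, `NS(=O)(=O)c1cccc(Nc2nccc(-c3cccnc3)n2)c1`: 200 nM
- compound 3, `NS(=O)(=O)c1cccc(Nc2nccc(-c3ccccn3)n2)c1`: 500 nM

In a functional assay for inhibition, with Homo sapiens as the target (a higher number here means a weaker inhibitor, a lower number a stronger inhibitor), compound 2 gives the lowest number of the three, with compound 3 at a 2.5-fold higher number from compound 2 to compound 3 (0.40 log units; beyond the scatter) and compound 1 further still. Compound 4, `CN(C)c1cccc(Nc2nccc(-c3cccnc3)n2)c1`, is not yet measured. It differs from compound 2 in one place: dimethylamino in place of sulfamoyl on an aromatic carbon.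

For the measured compounds named here, the only measured step, a 2.5-fold higher number from compound 2 to compound 3 (0.40 log units; beyond the scatter), changes a different part of the molecule and does not bear on this swap. Compound 1 carries dimethylamino but also a different aromatic ring, so its value against compound 2 mixes two changes. The expectation for compound 4 is therefore a weakening step, a 5.0-fold higher number from compound 2 to compound 4 (0.70 log units; beyond the scatter), with wide uncertainty. Compound 4 is estimated at 1000 nM, within 350 nM to 3000 nM.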

Compound 4, half-maximal inhibitory concentration: 1800 nM
Compound 4: middle estimate off by 1.8-fold (0.26 log units), on the low side, and the stated range covers the measured number.
By their numbers in this assay, from the lowest: compound 2; then compound 3; then compounds 4 and 1 (each within the scatter of the next).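

In this assay, the sulfamoyl group can now be compared directly with dimethylamino on an otherwise unchanged molecule, and the swap gives a 9.0-fold higher number from compound 2 to compound 4 (0.95 log units; beyond the scatter). With dimethylamino in place, exchanging thiophen-2-yl for pyridin-3-yl gives a 1.3-fold lower number from compound 1 to compound 4 (0.12 log units; within the scatter), so this ring change has no effect that can be told from the scatter. No evidence here explains the loss from removing sulfamoyl.

As far as these compounds go, whether a carboxylic acid or a methylsulfonyl group at this position would match sulfamoyl remains open. From the compounds shown here alone, it is also open whether the swap would cost as much in a molecule carrying pyridin-2-yl.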